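A few compounds are considered here, and "the series" means these few. Any claim that something is new, unique, unknown or untested is made for them only; others in the source may bear on it.

Measured so far in an assay on CHO cells for antagonist activity at transient receptor potential cation channel subfamily V member 1 (Homo sapiens), read by FLIPR; a lower number here means a stronger inhibitor, a higher number a weaker inhibitor:
compound 1 `CC(C(=O)NCc1ccc(C(F)(F)F)cc1N1CCCCCC1)c1ccc(NS(C)(=O)=O)c(F)c1` gives 1.6 nM
compound 2 `CC(C(=O)NCc1ccc(C(F)(F)F)cc1OC1CCCC1)c1ccc(NS(C)(=O)=O)c(F)c1` gives 0.6 nM

Compound 2 stands lowest of these two numbers; its nearest neighbour is compound 1, and the step of a 2.7-fold lower number from compound 1 to compound 2 (0.43 log units; beyond the scatter) lies beyond the scatter. Compound 3 `CC(C(=O)NCc1ccc(C(F)(F)F)cc1OCc1ccc(F)cc1)c1ccc(NS(C)(=O)=O)c(F)c1` differs from compound 2 by 4-fluorobenzyl in place of cyclopentyl on an oxygen on an aromatic ring. Within the data shown here, no measured step touches the group on this oxygen, so the only guide is that the earlier step was modest. A change of similar or smaller size is expected, in either direction, and so compound 3 is estimated at 1 nM (range 0.3 nM to 4 nM), which would mean an expected step of a 1.7-fold higher number from compound 2 to compound 3 (0.22 log units; within the scatter).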

Compound 3, inhibition constant: 0.5 nM
Compound 3: middle estimate off by 2.0-fold (0.30 log units), on the high side; the range from low to high includes it.
By their numbers in this assay, from the lowest: compounds 3 and 2 (each within the scatter of the next); then compound 1.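

In this assay, the oxygen on the aromatic ring carries cyclopentyl or 4-fluorobenzyl with no difference beyond the scatter (a 1.2-fold lower number from compound 2 to compound 3 (0.08 log units; within the scatter)), so this position accepts an aromatic ring as well as a non-aromatic one. The advantage over azepan-1-yl also holds for this second oxygen-linked group (a 3.2-fold lower number from compound 1 to compound 3 (0.51 log units; beyond the scatter)). Nothing available explains either result. Still open, going by these compounds, is whether the oxygen itself matters, since azepan-1-yl also differs from both oxygen-linked groups in its ring. Also open, on these data alone, is whether a small methyl or a longer chain ending in an amine on this oxygen would keep the number this low.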